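The compounds below may be only part of what the source reports. "The series", "measured", "known", "first", "only" and "open" are said of these compounds alone.

Of the compounds shown here, three of a shared core have been measured in an assay on cells for inhibition of Voltage-dependent T-type calcium channel subunit alpha-1H (Homo sapiens), read by patch clamp, tested at 10 uM; a lower number here means less inhibition, a higher number more inhibition at the concentration tested (going by the name of the read-out). Compound 1 `O=C(CC1c2ccccc2N=C(SCCCCCN2CCCC2)N1c1ccc(-c2ccccc2)cc1)NCc1ccc(F)cc1` gives 69% there. Compound 2 `CN(C)CCCCCSC1=Nc2ccccc2C(CC(=O)NCc2ccccc2)N1c1ccc(-c2ccccc2)cc1` gives 83.9% in this assay. Compound 3 `O=C(CC1c2ccccc2N=C(SCCCCCN2CCCC2)N1c1ccc(-c2ccc(F)cc2)cc1)NCc1ccccc1` gives 97.5% in this assay, the highest of the three numbers; its gap to compound 2 and its larger gap to compound 1 both lie beyond the usual scatter, so compound 3 has the highest inhibition in this assay as measured. Compound 4 `O=C(CC1c2ccccc2N=C(SCCCCCN2CCCC2)N1c1ccc(-c2ccccc2)cc1)NCc1ccccc1` has not yet been measured in this assay. It differs from compound 3 in one place: hydrogen in place of fluoro on an aromatic carbon. Among the compounds with values here, no pair among the measured compounds differs in exactly this way, so the size of this step is not known from the data. Since compound 3 sits at the top of the set and the change removes the fluoro, a moderate decrease is expected rather than none, the step from compound 3 to compound 4 in this assay being estimated at a number 13.5 percentage points lower from compound 3 to compound 4 (beyond the scatter). Compound 4 is therefore expected to give about 84% in this assay, with a range from 66% to 97%.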

Compound 4, a percentage reported as inhibition, at one concentration (the size of the read-out at that concentration, not a potency): 73.1%
For compound 4 the middle estimate is 10.9 percentage points above the measured one, within the range that was stated.
By their numbers in this assay, from the lowest: compounds 1 and 4 (each within the scatter of the next); then compound 2; then compound 3.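

In this assay, the change from 4-fluorophenyl to phenyl gives a number 24.4 percentage points lower from compound 3 to compound 4 (beyond the scatter), so at this position, para to a large group, the fluoro matters for inhibition at the concentration tested, whereas the same exchange of hydrogen for fluoro on a different aromatic ring gives a number 4.1 percentage points higher from compound 1 to compound 4 (within the scatter). With the 4-fluorophenyl gone, the amine at the end of the chain also shows an effect on the read-out, as pyrrolidin-1-yl in place of dimethylamino gives a number 10.8 percentage points lower from compound 2 to compound 4 (beyond the scatter). No measurement at hand accounts for either step.

As far as these compounds go, it remains open whether chloro, methoxy or a nitrile at this position would match fluoro. Also open, from the compounds shown here alone, is whether the fluoro step carries over to compounds with dimethylamino or a piperidine at the end of the chain.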